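This account rests on a few compounds, and the source may have more. Where it says the series, first, only, none or still open, it means among the compounds named here.

Compound 1 `CCOC(=O)C(CCCCCN)CSC(C)=O` is the weakest of the three measured compounds in an assay on isolated protein for inhibition of carboxypeptidase B (Sus scrofa), read by spectrophotometry, with stated times of 10 min and 30 min (on this read-out higher numbers stand for weaker inhibition and lower numbers for stronger inhibition), where compound 1 gives 19000 nM. Compound 2 `NCCCCCC(C[Se]C(=O)CCc1ccccc1)C(=O)O` gives 1400 nM in this assay, and compound 3 `CC(=O)SCC(CCCCCN)C(=O)O` gives 1400 nM; these two values lie within the scatter of each other, so nothing separates them. Among the measured compounds shown here, the one step recorded among the measured compounds is a 14-fold lower number from compound 1 to compound 3 (1.13 log units; beyond the scatter), which replaces the ethyl ester of compound 1 with a free acid.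

Compound 4 `CCOC(=O)C(CS)CCCCCN` keeps the ethyl ester of compound 1 and alters a different part of the molecule: hydrogen in place of acetyl on a sulfur. For the measured compounds named here, no measured step touches this position; the step from compound 1 to compound 3 concerns the oxygen of the ester and says nothing about the sulfur. The data therefore hold no direct guide for this change, and the expectation has to rest on compound 1 alone, with a wide allowance in either direction. Compound 4 is expected to give 6000 nM in this assay, within a range of 600 nM to 40000 nM. This estimate corresponds to an expected step of a 3.2-fold lower number from compound 1 to compound 4 (0.50 log units; beyond the scatter), one that could equally fall within the scatter.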

Compound 4, half-maximal inhibitory concentration: 260000 nM
Compound 4: the middle estimate sits 43-fold (1.64 log units) below what was measured, and the stated range ends below it.
By their numbers in this assay, from the lowest: compounds 2 and 3 (each within the scatter of the next); then compound 1; then compound 4.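

Taking the acetyl off the sulfur in this assay gives a 14-fold higher number from compound 1 to compound 4 (1.14 log units; beyond the scatter), so this position, on a sulfur whose other neighbours are a saturated chain carbon, proves sensitive, and the change leads to weaker inhibition. Among the compounds shown here, compounds 1 and 3 both carry the acetylsulfanyl group, so they could not show how a free sulfanyl group compares, and compound 4 is the first direct reading of that difference. The change at the sulfur is about as large as the change at the ester, which gives a 14-fold lower number from compound 1 to compound 3 (1.13 log units; beyond the scatter), but it runs the opposite way, and nothing available gives a measured reason for the effect at the sulfur.

On these data alone, it remains open whether the same step would appear with a free sulfanyl group alongside the carboxylic acid of compound 3 in place of the ethyl ester, since all that is known of this change comes from the ester series. As far as these compounds go, it is equally open whether the acetyl itself matters or whether another group on the sulfur, such as a benzoyl or a methyl, would serve as well.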